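The compounds below may be only part of what the source reports. "The series", "measured", "known", "first", "only" and "open" are said of these compounds alone.

Working notes on the series. For the measured compounds named here, compound 2 `CCCCCCc1cncc(OC[C@@H]2CCCN2C)c1` is the higher of the two numbers so far: in an assay on membranes from brain for displacement of a labelled ligand from Neuronal acetylcholine receptor; alpha4/beta2 (Rattus norvegicus) (on this read-out higher numbers stand for weaker inhibition and lower numbers for stronger inhibition), compound 2 gives 0.32 nM, and its nearest neighbour, compound 1 `CCCCc1cncc(OC[C@@H]2CCCN2C)c1`, gives 0.16 nM. Going by the values given here, the one step measured between them, a 2.0-fold higher number from compound 1 to compound 2 (0.30 log units; within the scatter), is the only change so far on the saturated chain and stays within the scatter.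

Compound 3 `CN1CCC[C@H]1COc1cncc(F)c1` differs from compound 2 by fluoro in place of hexyl on an aromatic carbon. Among the compounds with values here, no measured step swaps the chain for a halogen, so the only guidance is that lengthening the chain from compound 1 to compound 2 did not move the number beyond the scatter. Removal of the chain is taken to leave the number near where compound 2 stands, with a wider range to cover the untested change. Compound 3 is therefore expected at 0.4 nM, range 0.1 nM to 2 nM, which means an expected step of a 1.3-fold higher number from compound 2 to compound 3 (0.10 log units; within the scatter).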

Compound 3, inhibition constant: 0.69 nM
The estimate for compound 3 lay 1.7-fold (0.24 log units) below the measured number; measured number inside the range.
By their numbers in this assay, from the lowest: compounds 1 and 2 (each within the scatter of the next); then compound 3.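

In this assay, for the compounds shown here, swapping the chain for a halogen on this aromatic carbon gives the first steps to lie beyond the scatter: fluoro in place of hexyl gives a 2.2-fold higher number from compound 2 to compound 3 (0.33 log units; beyond the scatter), and fluoro in place of butyl gives a 4.3-fold higher number from compound 1 to compound 3 (0.63 log units; beyond the scatter). Both steps are modest, so among the compounds shown, a saturated chain on this carbon is not needed for a low number, although both chain compounds give lower numbers than the fluoro compound. Nothing available explains the size of these steps.

It remains open whether the steps follow from losing the chain or from the fluoro itself, as none of the compounds shown carries hydrogen, chloro or methoxy on this carbon. As far as these compounds go, how a methyl group or an octyl chain would read here also remains open.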